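Fluoro to Chloro on the Aromatic Ring

The source may report more compounds than this note shows. Statements on the series, on what has been measured and on what is new or still open speak of the compounds shown alone.

Compound 2 `CC(C)(C)n1ncc(OCc2nnc(-c3ccc(Cl)cc3F)o2)c(Cl)c1=O` gives 10400 nM in a functional assay on the whole organism for inhibition, with Mythimna separata as the target, with a stated time of 5 days (on this read-out lower numbers stand for an effect already at smaller amounts and higher numbers for an effect only at larger amounts of compound), and stands at the lower end of the two numbers shown, though compound 1 `Cc1ccc(-c2nnc(COc3cnn(C(C)(C)C)c(=O)c3Cl)o2)cc1` with 19900 nM lies within the scatter of it, as the step of a 1.9-fold lower number from compound 1 to compound 2 (0.28 log units; within the scatter) shows. Compound 3 `CC(C)(C)n1ncc(OCc2nnc(-c3ccc(Cl)cc3Cl)o2)c(Cl)c1=O` differs from compound 2 by chloro in place of fluoro on an aromatic carbon. Going by the values given here, no measured step exchanges one halogen for another at this carbon, and the single measured step is itself within the scatter, so no movement beyond the scatter is expected in this assay, the expected step being a 1.2-fold lower number from compound 2 to compound 3 (0.09 log units; within the scatter). Compound 3 is therefore estimated at 8500 nM, between 3000 nM and 25000 nM.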

Compound 3, half-maximal effective concentration: 27800 nM
For compound 3 the middle estimate is 3.3-fold (0.51 log units) below the measured one, outside the stated range (above it).
By their numbers in this assay, from the lowest: compounds 2, 1 and 3 (each within the scatter of the next, the first and the last beyond it).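

Going by these compounds alone, at the aromatic carbon ortho to a large group, the choice of halogen registers in this assay: chloro in place of fluoro gives a 2.7-fold higher number from compound 2 to compound 3 (0.43 log units; beyond the scatter), the first single-place change to lie beyond the scatter. The 2,4-dichlorophenyl in place of 4-methylphenyl change, by contrast, gives a 1.4-fold higher number from compound 1 to compound 3 (0.15 log units; within the scatter), so that exchange does not separate the two compounds. The data offer no measured explanation for the halogen step. Open, going by these compounds, is how a methoxy group or an amine at this carbon would read out, and whether the same halogen exchange behaves alike elsewhere on the ring.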